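The compounds below may be only part of what the source reports. "The series", "measured", "known", "first", "only" and "open" are said of these compounds alone.

Compound 3, `Cc1nc(S(C)(=O)=O)ccc1Oc1ncnc(OC2CCN(C(=O)OC3(C(F)(F)F)COC3)CC2)c1F`, gives 342 nM in a functional assay on isolated protein for inhibition of Glucose-dependent insulinotropic receptor (Rattus norvegicus), read by HTRF and cAMP accumulation (a lower number here means that less compound is needed, a higher number that more compound is needed for the effect), the highest of the three numbers measured. Its neighbours in that set share the core and differ only in the group on the oxygen next to the carbonyl: compound 1, `Cc1nc(S(C)(=O)=O)ccc1Oc1ncnc(OC2CCN(C(=O)O[C@@H](C)C(F)(F)F)CC2)c1F`, gives 109 nM, and compound 2, `Cc1nc(S(C)(=O)=O)ccc1Oc1ncnc(OC2CCN(C(=O)OC3(C(F)(F)F)CCC3)CC2)c1F`, gives 63.3 nM. Going a 1.7-fold lower number from compound 1 to compound 2 (0.24 log units; within the scatter) stays within the scatter, while a 3.1-fold higher number from compound 1 to compound 3 (0.50 log units; beyond the scatter) and a 5.4-fold higher number from compound 2 to compound 3 (0.73 log units; beyond the scatter) both run beyond it, so the 3-(trifluoromethyl)oxetan-3-yl group sits at the weak end of this small series.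

Compound 4, `Cc1nc(S(C)(=O)=O)ccc1Oc1ncnc(OC2CCN(C(=O)SC(C)C)CC2)c1F`, takes the change (isopropylsulfanyl in place of (3-(trifluoromethyl)oxetan-3-yl)oxy on a carbonyl carbon). The steps 1>3 and 2>3 bear on this: both left the oxetane-bearing compound 3 with a higher number than its acyclic or carbocyclic partners, so moving away from that group toward a short acyclic substituent is expected to bring the number down. Compound 4 is therefore expected at 120 nM, with a range from 40 nM to 400 nM. That expectation means a step of a 2.9-fold lower number from compound 3 to compound 4 (0.45 log units; beyond the scatter) in this assay.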

Compound 4, half-maximal effective concentration: 41.3 nM
Beside the measured number, compound 4's estimate is 2.9-fold (0.46 log units) above it; the measured number falls inside the stated range.
By their numbers in this assay, from the lowest: compounds 4, 2 and 1 (each within the scatter of the next, the first and the last beyond it); then compound 3.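

The sulfur-linked isopropylsulfanyl group, with no ring and no fluorine, reaches the low end of this series in this assay: the change gives an 8.3-fold lower number from compound 3 to compound 4 (0.92 log units; beyond the scatter) and also a 2.6-fold lower number from compound 1 to compound 4 (0.42 log units; beyond the scatter), both beyond the scatter, while a 1.5-fold lower number from compound 2 to compound 4 (0.19 log units; within the scatter) stays within it. Within the data shown here, this position on the carbonyl carbon therefore keeps low numbers without a trifluoromethyl group, an oxygen link or a ring, none of which the earlier compounds could show. Nothing measured here explains the change.

The compounds shown do not separate the effect of the sulfur link from that of the isopropyl group. Going by these compounds, an isopropoxy group or an isopropylamino group on the same carbonyl carbon would bear on that, and how either would read remains open.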